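Moving the trifluoromethyl group: what compound 4 may show

The compounds below may be only part of what the source reports. "The series", "measured", "known", "first", "only" and "open" are said of these compounds alone.

Three compounds sharing one core have been measured in an ADME assay on MT4 cells (Homo sapiens) for cytotoxicity, read by MTT assay, with a stated time of 4 days; a higher number here means that more compound is tolerated, a lower number that less compound is tolerated:

compound 1 `Cc1cc(-c2ccccc2C(F)(F)F)cc(C)c1Nc1ccnc(Nc2ccc(C#N)cc2)n1` gives 4210 nM
compound 2 `Cc1cc(-c2c(C)cccc2C)cc(C)c1Nc1ccnc(Nc2ccc(C#N)cc2)n1` gives 2590 nM
compound 3 `Cc1cc(-c2cc(F)cc(F)c2)cc(C)c1Nc1ccnc(Nc2ccc(C#N)cc2)n1` gives 3910 nM

Compound 1 has the highest of the three numbers, yet its nearest neighbour is compound 3 with a 1.1-fold lower number from compound 1 to compound 3 (0.03 log units; within the scatter) and its furthest is compound 2 with a 1.6-fold lower number from compound 1 to compound 2 (0.21 log units; within the scatter), both within the scatter, so no order among the three can be claimed. The remaining pair shows a 1.5-fold higher number from compound 2 to compound 3 (0.18 log units; within the scatter), also within the scatter.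

Compound 4 `Cc1cc(-c2cccc(C(F)(F)F)c2)cc(C)c1Nc1ccnc(Nc2ccc(C#N)cc2)n1` has not yet been measured. It differs from compound 1 by 3-(trifluoromethyl)phenyl in place of 2-(trifluoromethyl)phenyl on an aromatic carbon, the two having the same atoms joined differently. Each measured change at this aromatic carbon, whether a 2,6-dimethylphenyl or a 3,5-difluorophenyl entered in place of the 2-(trifluoromethyl)phenyl, left this assay unchanged beyond the scatter, and a rearrangement within the same group is expected to do likewise. The estimated step is a 1.1-fold lower number from compound 1 to compound 4 (0.02 log units; within the scatter) in no particular direction. Compound 4 is therefore expected to give about 4000 nM, within a range from 2000 nM to 8000 nM.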

Compound 4, half-maximal cytotoxic concentration: 4030 nM
The estimate for compound 4 lay 1.0-fold (0.00 log units) below the measured number; the measured number falls inside the stated range.
By their numbers in this assay, from the lowest: compounds 2, 3, 4 and 1 (each within the scatter of the next).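

Going by these compounds alone, compound 4 carries the same atoms as compound 1, joined differently, so this is the first change at this aromatic carbon that rearranges a group without exchanging it. In this assay, 3-(trifluoromethyl)phenyl in place of 2-(trifluoromethyl)phenyl gives a 1.0-fold lower number from compound 1 to compound 4 (0.02 log units; within the scatter) and so does not separate the two arrangements, while the other two comparisons, a 1.0-fold higher number from compound 3 to compound 4 (0.01 log units; within the scatter) and a 1.6-fold higher number from compound 2 to compound 4 (0.19 log units; within the scatter), also stay within the scatter. All four groups at this position therefore remain indistinguishable in this cytotoxicity read-out, and no supporting data are available to explain this.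

All four compounds carry a substituted phenyl group at this carbon, each bearing only methyl, fluorine or trifluoromethyl. From the compounds shown here alone, whether an amine or a carboxylic acid on that phenyl ring would shift the number beyond the scatter remains open.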